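Cyclopropyl to isopropyl: working notes on the series

The source may report more compounds than this note shows. Statements on the series, on what has been measured and on what is new or still open speak of the compounds shown alone.

Compound 1 `CC(C)(C)NCCCOc1ccc(S(=O)(=O)c2c(C3CC3)cn3ccccc23)cc1`: 66.5 nM
Compound 2 `CCCCN(CCCC)CCCOc1ccc(S(=O)(=O)c2c(C3CC3)cn3ccccc23)cc1`: 10.9 nM
Compound 3 `CCc1cn2ccccc2c1S(=O)(=O)c1ccc(OCCCN2CCCCC2)cc1`: 357 nM

All three values come from a functional assay (aorta) with Rattus norvegicus as the target; a higher number here means a weaker inhibitor, a lower number a stronger inhibitor. Compound 1 holds the second highest of the three numbers, with a higher number for compound 3 and a lower one for compound 2.

Compound 4 `CC(C)c1cn2ccccc2c1S(=O)(=O)c1ccc(OCCCNC(C)(C)C)cc1` has not yet been measured. It carries isopropyl in place of cyclopropyl on an aromatic carbon of the core of compound 1: isopropyl in place of cyclopropyl on an aromatic carbon.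

Among the compounds with values here, the only measured step, a 6.1-fold lower number from compound 1 to compound 2 (0.79 log units; beyond the scatter), is modest but beyond the scatter. It replaces (tert-butyl)amino with dibutylamino, elsewhere in the molecule, so it gives no direct size for this change. Within the data shown here, compound 3 differs from compound 1 in more than one place, so its value gives no clean step either. Among the measured compounds shown here, no measured step covers this place, and no step beyond the scatter is expected in this assay.

The expected step is a 1.1-fold higher number from compound 1 to compound 4 (0.02 log units; within the scatter). The estimate for compound 4 is 70 nM. The estimated range for compound 4 runs from 22 nM to 220 nM.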

Compound 4, half-maximal inhibitory concentration: 41.8 nM
Compound 4: the middle estimate sits 1.7-fold (0.22 log units) above what was measured, within the range that was stated.
By their numbers in this assay, from the lowest: compound 2; then compounds 4 and 1 (each within the scatter of the next); then compound 3.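

In this assay, within the data shown here, isopropyl in place of cyclopropyl on this aromatic carbon gives a 1.6-fold lower number from compound 1 to compound 4 (0.20 log units; within the scatter), the first direct reading at this position, since the earlier step changed only the amine end of the chain. With (tert-butyl)amino held fixed, the three-membered ring can therefore give way to an open group of the same heavy-atom count without a step beyond the scatter. No measurement on hand accounts for this outcome.

Going by these compounds, whether the same exchange holds with dibutylamino at the chain end remains open, and compound 3 differs from compound 1 in more than one place, so it gives no clean reading for ethyl. The compounds shown also leave open how cyclobutyl, phenyl or a carboxylic acid on this aromatic carbon would compare.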